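The source may hold more compounds than are shown below. What is called first, only, known or untested is meant among the compounds shown, and "the series" means these compounds.

Measured so far:
compound 1 `COC(=O)/C=C/c1cccc(N(Cc2ccc(/C=C/c3cccc(F)c3)cc2)C(=O)NC(C)C)c1` — 468 nM
compound 2 `COC(=O)/C=C/c1cccc(N(Cc2ccc(/C=C/c3ccc(F)cc3)cc2)C(=O)C2CCCCC2)c1` — 186 nM
compound 3 `COC(=O)/C=C/c1cccc(N(Cc2ccc(-c3cccc(OC)c3)cc2)C(=O)C(C)C)c1` — 72.4 nM

In an assay on isolated protein with Bile acid receptor (Homo sapiens) as the target (on this read-out higher numbers stand for an effect only at larger amounts of compound and lower numbers for an effect already at smaller amounts), compound 1 stands highest of the three numbers; compound 2 lies nearer to it, compound 3 furthest below it, both gaps beyond the scatter. Compound 4 `COC(=O)/C=C/c1cccc(N(Cc2ccc(-c3cccc(C)c3)cc2)C(=O)NC(C)C)c1` is not yet measured. It differs from compound 1 in one place: 3-methylphenyl in place of 2-(3-fluorophenyl)ethenyl on an aromatic carbon. Going by the values given here, no measured pair isolates this change; compound 3, which also carries a directly attached aryl group, differs from compound 1 at the amide as well, so its lower number cannot be assigned to the aryl alone. A moderate drop is nonetheless expected, the step of a 2.3-fold lower number from compound 1 to compound 4 (0.37 log units; beyond the scatter) estimated to lie beyond the scatter. For compound 4 the value in this assay is expected near 200 nM, with a range of 70 nM to 600 nM.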

Compound 4, half-maximal effective concentration: 1320 nM
Estimate against measurement, compound 4: 6.6-fold (0.82 log units) below, outside the stated range (above it).
By their numbers in this assay, from the lowest: compound 3; then compound 2; then compound 1; then compound 4.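

Replacing 2-(3-fluorophenyl)ethenyl with 3-methylphenyl on this aromatic carbon, para to a large group, gives a 2.8-fold higher number from compound 1 to compound 4 (0.45 log units; beyond the scatter) in this assay. This is the only single-place comparison shown, and it demonstrates that this position responds to the change, with the ethenyl-linked group giving the lower number. No available evidence accounts for the step. As far as these compounds go, it remains open whether the step follows from losing the double bond or from exchanging fluorine for methyl. Also open, from the compounds shown here alone, is how a carboxylic acid in place of the methyl ester would read.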